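The source may hold more compounds than are shown below. What is called first, only, known or untested is meant among the compounds shown, and "the series" means these compounds.

Of the compounds shown here, two have numbers so far. Compound 1 `CC(C)CCN1CCN(C(=O)C[C@H](Cc2ccc(Cl)cc2)C(=O)N2CCN(c3ccccc3N(CC3CC3)S(C)(=O)=O)CC2)CC1` gives 4.8 nM in an assay on isolated protein for binding affinity to Melanocortin receptor 4 (Homo sapiens); a higher number here means a weaker inhibitor, a lower number a stronger inhibitor. Compound 2 `CS(=O)(=O)N(CC1CC1)c1ccccc1N1CCN(C(=O)[C@H](CC(=O)N2CCN(CC3CC3)CC2)Cc2ccc(Cl)cc2)CC1` gives 3 nM in this assay; the change from compound 1 to compound 2 is cyclopropyl in place of isobutyl on a saturated chain carbon bound to an amine nitrogen in a ring, and it moved the number by a 1.6-fold lower number from compound 1 to compound 2 (0.20 log units; within the scatter). Compound 2 thus holds the lower of the two numbers, though its gap to compound 1 is within the scatter.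

Compound 3 `CC(=O)N1CCN(C(=O)C[C@H](Cc2ccc(Cl)cc2)C(=O)N2CCN(c3ccccc3N(CC3CC3)S(C)(=O)=O)CC2)CC1` differs from compound 2 by acetyl in place of cyclopropylmethyl on an amine nitrogen in a ring. For the measured compounds named here, the one measured step touches the same ring nitrogen, and it was small, but it swapped one alkyl chain for another, whereas here a cyclopropylmethyl gives way to an acetyl; no measured pair covers that kind of change. A modest rise in the number, with wide uncertainty, is expected for compound 3 in this assay, namely a 5.0-fold higher number from compound 2 to compound 3 (0.70 log units; beyond the scatter). Compound 3 is estimated at 15 nM, between 3 nM and 80 nM.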

Compound 3, half-maximal inhibitory concentration: 11 nM
For compound 3 the middle estimate is 1.4-fold (0.13 log units) above the measured one, and the stated range covers the measured number.
By their numbers in this assay, from the lowest: compounds 2 and 1 (each within the scatter of the next); then compound 3.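

The earlier pair only swapped one alkyl group for another on this ring nitrogen, whereas compound 3 carries an acetyl, which adds a hydrogen-bond acceptor and a double bond outside aromatic rings. In this assay the acetyl gives a 3.7-fold higher number from compound 2 to compound 3 (0.56 log units; beyond the scatter) and a 2.3-fold higher number from compound 1 to compound 3 (0.36 log units; beyond the scatter) and both steps are modest, so this nitrogen is sensitive to at least this kind of replacement, though the change is not large. Nothing available gives a reason for this shift.

Going by these compounds, whether the shift follows the carbonyl itself or simply the loss of an alkyl group remains open. A methanesulfonyl group, a longer acyl chain such as propanoyl, or a plain hydrogen on this nitrogen would help separate those two readings.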